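Replacing Butyl on the Carbonyl Carbon of Compound 3

The source may report more compounds than this note shows. Statements on the series, on what has been measured and on what is new or still open speak of the compounds shown alone.

Of the compounds shown here, three sharing one core have been tested in a functional assay on PC-3 cells (Homo sapiens) for antiproliferative activity, read by MTT assay, with a stated time of 72 h; on this read-out lower numbers stand for stronger inhibition and higher numbers for weaker inhibition. Compound 1 `CCn1cc(C(CC)(CC)c2ccc(C#CC(O)(CC)CC)c(C)c2)cc1C(=O)NCC(=O)OC` gives 17500 nM, compound 2 `CCN(CC)CCNC(=O)c1cc(C(CC)(CC)c2ccc(C#CC(O)(CC)CC)c(C)c2)cn1CC` gives 5350 nM, and compound 3 `CCCCC(=O)c1cc(C(CC)(CC)c2ccc(C#CC(O)(CC)CC)c(C)c2)cn1CC` gives 48100 nM, the highest number and so the weakest of the three.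

Next comes compound 4 `CCn1cc(C(CC)(CC)c2ccc(C#CC(O)(CC)CC)c(C)c2)cc1C(=O)NCC(=O)O`, with (carboxymethyl)amino in place of butyl on a carbonyl carbon. Going by the values given here, two measured steps bear on this change, both running the opposite way, with butyl entering at that carbon. One is a 2.7-fold higher number from compound 1 to compound 3 (0.44 log units; beyond the scatter), and the other is a 9.0-fold higher number from compound 2 to compound 3 (0.95 log units; beyond the scatter). Both raised the number, so removing butyl should lower it. The group leaving in the first step, ((methoxycarbonyl)methyl)amino, reads closest to the group entering now, so that smaller step is the better guide to size. No (carboxymethyl)amino compound has been measured yet, so the uncertainty is wide. The expected result is a modest gain, a 2.4-fold lower number from compound 3 to compound 4 (0.38 log units; beyond the scatter). For compound 4 the estimate is 20000 nM, with an expected range from 7000 nM to 60000 nM.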

Compound 4, half-maximal inhibitory concentration: 6300 nM
The estimate for compound 4 lay 3.2-fold (0.50 log units) above the measured number; measured number outside the range, below it.
By their numbers in this assay, from the lowest: compounds 2 and 4 (each within the scatter of the next); then compound 1; then compound 3.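

In this assay, exchanging butyl for (carboxymethyl)amino on this carbonyl carbon gives a 7.6-fold lower number from compound 3 to compound 4 (0.88 log units; beyond the scatter), so a side chain ending in a carboxylic acid is clearly preferred to butyl in this series. The far end of that chain also counts: removing only the methyl from the ester oxygen gives a 2.8-fold lower number from compound 1 to compound 4 (0.44 log units; beyond the scatter), while exchanging the (diethylamino)methyl end for carboxy gives a 1.2-fold higher number from compound 2 to compound 4 (0.07 log units; within the scatter), which lies within the scatter, so the acid and the amine cannot be told apart here. No measurement shown accounts for any of these shifts.

From the compounds shown here alone, whether a longer chain carrying the carboxylic acid, or a simple methyl amide on this carbonyl carbon, would lower the number further stays open. So does how much of the gain over butyl comes from the amide itself and how much from the end of the chain.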